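From Methoxy to Hydroxy on a Weak Growth Inhibitor

The source may report more compounds than this note shows. Statements on the series, on what has been measured and on what is new or still open speak of the compounds shown alone.

Of the compounds shown here, three have so far been tested in a functional assay on A549 cells (Homo sapiens) for inhibition, read by ELISA, with a stated time of 24 h; on this read-out higher numbers stand for weaker inhibition of growth and lower numbers for stronger inhibition of growth. Compound 1 (`CO/N=C/C=C/c1ccccc1OC(=O)c1ccccc1`) reads > 100000 nM, which is a limit of the assay and not a number. Compound 3 (`CN1CCN(C(=O)ONC(=O)/C=C/c2ccccc2OC(=O)c2ccccc2)CC1`) reads > 100000 nM, which is also a limit. Among the compounds with values here, compound 2 (`COc1ccccc1/C=C/C(=O)NO`) gives 53500 nM, the only true number in the set, so it is the single firm starting point.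

Compound 4 (`O=C(/C=C/c1ccccc1O)NO`) differs from compound 2 in one place: hydrogen in place of methyl on an oxygen on an aromatic ring. This puts hydrogen in place of methyl on an oxygen on an aromatic ring, turning methoxy into hydroxy. Within the data shown here, no pair of measured compounds shows what this exchange does in this assay, so the expectation rests on compound 2 at 53500 nM alone. No change beyond the usual scatter of repeated measurements is expected, in either direction. The expected step is a 1.2-fold lower number from compound 2 to compound 4 (0.08 log units; within the scatter). The estimate for compound 4 is 45000 nM, with an expected range from 18000 nM to 100000 nM.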

Compound 4, concentration for 50% growth inhibition: 55200 nM
Compound 4: middle estimate off by 1.2-fold (0.09 log units), on the low side; low and high end bracket the measured number.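

In this assay, replacing methoxy with hydroxy on the aromatic ring gives a 1.0-fold higher number from compound 2 to compound 4 (0.01 log units; within the scatter). Within the data shown here, this is the first direct reading of this exchange in the set: on this oxygen, hydrogen can stand in place of methyl without a change that rises out of the scatter of repeated measurements. The methyl is therefore not needed to keep the number where it stands, although that number remains high on a scale where lower numbers mean stronger inhibition of growth.

Going by these compounds, whether a longer chain on this oxygen, or an amine or a carboxylic acid at this place on the ring, would move the number remains open. The other compounds add no step that can be read, because their values stop at a limit: the limit of > 100000 nM in this assay, at which 2 of the 4 values shown sit.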